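One methoxy fewer on the core of compound 1

This account rests on a few compounds, and the source may have more. Where it says the series, first, only, none or still open, it means among the compounds named here.

Compound 1 `COc1cc2c(c(OC)c1)OCN(c1ccc3oc(-c4ccccc4)cc(=O)c3c1)C2` is measured in a functional assay on MCF7 cells (Homo sapiens) for inhibition, read by MTT assay, with a stated time of 48 h, tested at 15 ug/mL (a lower number here means less inhibition of growth, a higher number more inhibition of growth at the concentration tested), at 60%. Compound 2 `O=c1cc(-c2ccccc2)oc2cc(N3COc4c(Br)cccc4C3)ccc12` gives in this assay 5.64%, a number well below compound 1 and beyond the scatter. Of the two measured compounds, compound 1 stands highest. Among the compounds with values here, no pair of measured compounds differs in a single place, so the weight of one change on the shared core cannot yet be read from the numbers.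

Compound 3 `COc1cccc2c1OCN(c1ccc3oc(-c4ccccc4)cc(=O)c3c1)C2` has not been measured. Relative to compound 1 it differs as follows: hydrogen in place of methoxy on an aromatic carbon. Because compound 2 gives 5.64% with another substitution pattern on the same ring, while compound 1 gives 60%, a loss beyond the scatter is expected for compound 3, though smaller than the gap to compound 2. For compound 3 the expected value in this assay is 40%, within 15% to 62%. The expected step of a number 20 percentage points lower from compound 1 to compound 3 (beyond the scatter) is downward.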

Compound 3, percent growth inhibition at one concentration: 54%
For compound 3 the middle estimate is 14 percentage points below the measured one; the range from low to high includes it.
By their numbers in this assay, from the lowest: compound 2; then compounds 3 and 1 (each within the scatter of the next).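

Within the data shown here, this is the first single-place comparison: in this assay, hydrogen in place of methoxy gives a number 6 percentage points lower from compound 1 to compound 3 (within the scatter). At this aromatic carbon, meta to a fused ring and para to a fused ring, the methoxy group can therefore be exchanged for hydrogen without a change beyond the scatter, so this methoxy is not required for the growth inhibition seen at the concentration tested. No measurement at hand bears on why the exchange is tolerated.

The compounds shown leave open whether the remaining methoxy group contributes to the inhibition once it too is replaced by hydrogen. They also leave open how an amine or a carboxylic acid would behave at the position now carrying hydrogen.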